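Methyl on the pyrazole carbon: expectation for compound 4

The compounds below may be only part of what the source reports. "The series", "measured", "known", "first", "only" and "open" are said of these compounds alone.

Three compounds of the series have been run in an assay on isolated protein for binding affinity to Leucine-rich repeat serine/threonine-protein kinase 2 (Homo sapiens), read by TR-FRET and LanthaScreen, with a stated time of 2 h; on this read-out lower numbers stand for stronger inhibition and higher numbers for weaker inhibition. Compound 1 `C[C@@H]1CCCN1c1c(C#N)c2c(N)nc(Nc3cn[nH]c3)nc2n1C` gives 0.2 nM. Compound 2 `C[C@@H]1CCCN1c1c(C#N)c2c(N)nc(N)nc2n1C` carries hydrogen where compound 1 carries the 1H-pyrazol-4-yl group; in this assay compound 2 gives 6 nM; the step of a 30-fold higher number from compound 1 to compound 2 (1.48 log units; beyond the scatter) is large. Compound 3 `C[C@@H]1CCCN1c1c(C#N)c2c(N)nc(Nc3cnn(C)c3)nc2n1C` gives 0.1 nM, the lowest of the three numbers; its separation from compound 1, a 2.0-fold lower number from compound 1 to compound 3 (0.30 log units; within the scatter), stays within the scatter, whereas a 60-fold lower number from compound 2 to compound 3 (1.78 log units; beyond the scatter) is again large. Compound 3 thus sits at the low end of the three values, alongside compound 1.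

Compound 4 `Cc1c(Nc2nc(N)c3c(C#N)c(N4CCC[C@H]4C)n(C)c3n2)cnn1C` has not yet been measured. It differs from compound 3 by methyl in place of hydrogen on an aromatic carbon. Among the measured compounds shown here, the only measured step that bears on this is the other methyl on the same ring, methyl in place of hydrogen on an aromatic nitrogen, a 2.0-fold lower number from compound 1 to compound 3 (0.30 log units; within the scatter), which remained within the scatter. The two large steps, a 30-fold higher number from compound 1 to compound 2 (1.48 log units; beyond the scatter) and a 60-fold lower number from compound 2 to compound 3 (1.78 log units; beyond the scatter), concern the presence of the whole ring and say nothing about a methyl on its carbon. On this basis compound 4 is expected to show a 1.5-fold higher number from compound 3 to compound 4 (0.18 log units; within the scatter), no step beyond the scatter in this assay. Compound 4 is accordingly estimated at 0.15 nM, within a range of 0.05 nM to 0.5 nM.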

Compound 4, inhibition constant: 2 nM
For compound 4 the middle estimate is 13-fold (1.12 log units) below the measured one; the measured number lies above the stated range.
By their numbers in this assay, from the lowest: compounds 3 and 1 (each within the scatter of the next); then compound 4; then compound 2.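

Methyl on this aromatic carbon, next to the ring atom that bears a large group and next to the ring atom that bears a methyl group, behaves differently from methyl on the ring nitrogen: in this assay the carbon methyl gives a 20-fold higher number from compound 3 to compound 4 (1.30 log units; beyond the scatter), whereas the nitrogen methyl gave only a 2.0-fold lower number from compound 1 to compound 3 (0.30 log units; within the scatter). One added carbon thus removes most of the gain carried by the whole ring, leaving the 1,5-dimethyl-1H-pyrazol-4-yl group with a 3.0-fold lower number from compound 2 to compound 4 (0.48 log units; beyond the scatter) against the free amino group, and with a 10-fold higher number from compound 1 to compound 4 (1.00 log units; beyond the scatter) against the 1H-pyrazol-4-yl group. No measurement at hand accounts for this sensitivity.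

The compounds shown do not tell whether the shift belongs to methyl specifically or would also follow fluorine, a methoxy group or an ethyl group on the same carbon. They also leave open whether the carbon methyl gives a step of this size when the ring nitrogen carries hydrogen instead of methyl, and whether a methyl on the other ring carbon behaves in the same way.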